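Methyl-to-fluoro swaps on the aromatic ring, cytotoxicity notes

The source may hold more compounds than are shown below. What is called first, only, known or untested is meant among the compounds shown, and "the series" means these compounds.

Measured so far:
compound 1 `C/C(=C\c1cc(-c2ccc(C)cc2)co1)C(N)=O`: > 50000 nM
compound 2 `C/C(=C\c1cc(-c2ccc(F)cc2)co1)C(N)=O`: 14900 nM
compound 3 `C/C(=C\c1cc(-c2ccc(C)nc2)co1)C(N)=O`: > 50000 nM

In a functional assay on A549 cells (Homo sapiens) for cytotoxicity, read by CCK-8 assay, with a stated time of 24 h (on this read-out higher numbers stand for weaker inhibition and lower numbers for stronger inhibition), compound 1 gives > 50000 nM, which is a limit of the assay and not a number. Compound 2 gives 14900 nM in this assay. The step of an at least 3.3-fold lower number from compound 1 to compound 2 (0.52 log units; beyond the scatter) comes with the change (fluoro in place of methyl on an aromatic carbon). Compound 3 gives > 50000 nM in this assay, again a limit. Two of the three values sit at that limit, as the limit of > 50000 nM in this assay, at which 2 of the 3 values shown sit, shows. How the core of compound 3 differs from the core of compound 1 is not broken down here.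

Compound 4 `C/C(=C\c1cc(-c2ccc(F)nc2)co1)C(N)=O` is not yet measured. It differs from compound 3 by fluoro in place of methyl on an aromatic carbon. This is the same kind of change as from compound 1 to compound 2, but the place differs: in compound 2 the fluoro sits on a six-membered aromatic ring of carbon only, in compound 4 on a six-membered aromatic ring with 1 nitrogen, next to the ring nitrogen. For compound 4 the step of an at least 2.0-fold lower number from compound 3 to compound 4 (0.30 log units; that floor lies within the scatter) is expected in this assay, resting on the earlier step of an at least 3.3-fold lower number from compound 1 to compound 2 (0.52 log units; beyond the scatter) for the same kind of change. Compound 4 is estimated at 25000 nM in this assay, likely between 8000 nM and 60000 nM, with a real chance that only a limit is reported.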

Compound 4, half-maximal inhibitory concentration: > 50000 nM
Compound 4: no number, only a limit (the forecaster's own chance of this, stated with the estimate: 45%); at least 2.0-fold (0.30 log units) between middle value and limit.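

In this assay compound 4 gives > 50000 nM, a limit and not a number. For the compounds shown here, compound 3 also sits at a limit, so no step from compound 3 to compound 4 can be read. The compounds shown leave open whether fluoro in place of methyl changes the read-out at all on the six-membered aromatic ring with 1 nitrogen.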